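The source may hold more compounds than are shown below. What is called first, only, known or untested is meant among the compounds shown, and "the series" means these compounds.

Series notes. Three compounds carry numbers in a functional assay on RXF 393 cells (Homo sapiens) for cytotoxicity, read by sulforhodamine B assay, with a stated time of 48 h; on this read-out lower numbers stand for stronger inhibition of growth and higher numbers for weaker inhibition of growth. Compound 2 `ClCc1ccccc1Cn1cnc2ncnc(Cl)c21` gives 6540 nM in this assay, the lowest of the three. Compound 1 `ClCc1cccc(Cn2cnc3ncnc(Cl)c32)c1` gives 17400 nM, and compound 3 `ClCc1ccc(Cn2cnc3c(Cl)nc(Cl)nc32)cc1` gives 41700 nM; both gaps to compound 2 lie beyond the scatter. Compound 4 `ClCc1ccccc1Cn1cnc2nc(Cl)nc(Cl)c21` is not yet measured. Relative to compound 2 it carries chloro in place of hydrogen on an aromatic carbon. Among the measured compounds shown here, no measured pair differs in this single place, so the size of the step is unknown; compound 3, whose core also carries the extra chloro though on a different arm arrangement, gives 41700 nM, which weakly points toward weaker inhibition of growth. The expected step from compound 2 to compound 4 is a 1.7-fold higher number from compound 2 to compound 4 (0.23 log units; within the scatter). Compound 4 is estimated at 11000 nM, range 3500 nM to 35000 nM.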

Compound 4, concentration for total growth inhibition: 1900 nM
Estimate against measurement, compound 4: 5.8-fold (0.76 log units) above; measured number outside the range, below it.
By their numbers in this assay, from the lowest: compound 4; then compound 2; then compound 1; then compound 3.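

In this assay, among the compounds shown here, chloro in place of hydrogen on an aromatic carbon between two ring nitrogen atoms gives a 3.4-fold lower number from compound 2 to compound 4 (0.54 log units; beyond the scatter) and so provides the first single-place step, one beyond the scatter. This position therefore tolerates the chloro group, and on this arm arrangement the change moves toward stronger inhibition of growth. Nothing available bears on the reason for this step. Open, from the compounds shown here alone, is whether an amine or a methoxy group at this position would move the number in the same direction, and whether the same chloro change would give a similar step on the arm arrangement of compound 1.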